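The compounds below may be only part of what the source reports. "The series", "measured", "known", "first", "only" and "open" are said of these compounds alone.

Among the compounds with values here, compound 3 `N[C@H]1CC[C@H](Nc2c(C(=O)NCc3cccc(C(F)(F)F)c3)nc(Br)c3cccnc23)CC1` is the only one of the three compounds with a number in a functional assay on MDA-MB-435 cells (Homo sapiens) for cytotoxicity, read by MTT assay, with a stated time of 72 h; on this read-out lower numbers stand for stronger inhibition and higher numbers for weaker inhibition: compound 3 gives 4200 nM. Compound 1 `C[C@@H](CO)Nc1nc(C(=O)NCc2ccc(F)cc2)c(O)c2ncccc12` reaches only a limit in this assay, where compound 1 gives > 20000 nM. Compound 2 `N[C@H]1CC[C@H](Nc2c(C(=O)NCc3ccco3)nc(Br)c3cccnc23)CC1` also reaches only a limit in this assay, where compound 2 gives > 10000 nM. Within the data shown here, the single measured step, an at least 2.3-fold lower number from compound 2 to compound 3 (0.37 log units; beyond the scatter), is the only guide to how the group on the amide-type nitrogen matters here. Compound 4 `N[C@H]1CC[C@H](Nc2c(C(=O)Nc3ccccc3)nc(Br)c3cccnc23)CC1` differs from compound 3 by phenyl in place of 3-(trifluoromethyl)benzyl on an amide-type nitrogen. This is not the reverse of the measured step, but it removes the 3-(trifluoromethyl)benzyl group whose arrival produced an at least 2.3-fold lower number from compound 2 to compound 3 (0.37 log units; beyond the scatter), so the number is expected to rise again toward the limit at which compound 2 sits, (the limit of > 10000 nM in this assay, at which 1 of the 3 values shown sits). Compound 4 is therefore expected to give 12000 nM in this assay, with a range from 4000 nM to 30000 nM. The expected step is a 2.9-fold higher number from compound 3 to compound 4 (0.46 log units; beyond the scatter), a weakening beyond the scatter.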

Compound 4, half-maximal inhibitory concentration: 1000 nM
Estimate against measurement, compound 4: 12-fold (1.08 log units) above, outside the stated range (below it).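

In this assay, the 3-(trifluoromethyl)benzyl group proved unnecessary for the lowest number seen so far at this position, since phenyl in its place on the amide-type nitrogen gave a 4.2-fold lower number from compound 3 to compound 4 (0.62 log units; beyond the scatter). The same phenyl in place of (furan-2-yl)methyl gave an at least 10-fold lower number from compound 2 to compound 4 (1.00 log units; beyond the scatter), so the ring set directly on the amide-type nitrogen outdid both groups that hold their ring on a saturated chain carbon, although it is the smaller group, with fewer heavy atoms than 3-(trifluoromethyl)benzyl. This last step rests on a limit and not a number for compound 2: the limit of > 10000 nM in this assay, at which 1 of the 4 values shown sits.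

The compounds shown do not tell whether 3-(trifluoromethyl)phenyl on this nitrogen would lower the number further. They also leave open how a longer chain such as 2-phenylethyl, or a phenyl ring carrying an amine or a carboxylic acid, would fare here.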